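The compounds below may be only part of what the source reports. "The series", "measured", "known", "first", "only" and "open" are said of these compounds alone.

Series notes. The shared core of compound 1 `CCCNC(=C\C(=O)/C=C/c1ccc(O)c(OC)c1)/C=C/c1ccc(O)c(OC)c1` carries a propyl group on the amine nitrogen; in a functional assay for inhibition, read by spectrophotometry, with a stated time of 30 min, tested at 1 uM (on this read-out higher numbers stand for more inhibition at the one concentration tested (going by the name of the read-out) and lower numbers for less inhibition), compound 1 gives 0.1%, the highest of the three numbers, though the gaps to the others lie within the scatter. Compound 2 `CCC(C)NC(=C\C(=O)/C=C/c1ccc(O)cc1)/C=C/c1ccc(O)cc1` gives 0.03% and compound 3 `O=C(/C=C(/C=C/c1ccc(O)cc1)NC1CCCCC1)/C=C/c1ccc(O)cc1` gives 0.03%. Within the data shown here, the one measured step that changes the group on the amine nitrogen, no change at the digits printed from compound 2 to compound 3 (within the scatter), shows nothing beyond the scatter. Compound 4 `CCCCNC(=C\C(=O)/C=C/c1ccc(O)c(OC)c1)/C=C/c1ccc(O)c(OC)c1` differs from compound 1 by methyl in place of hydrogen on a saturated chain carbon, three bonds along the chain from an amine nitrogen. Among the measured compounds shown here, since that step, like the one from compound 2 to compound 3, only lengthens the chain on the amine nitrogen, no change beyond the scatter is expected in this assay, with no change at the digits printed from compound 1 to compound 4 (within the scatter). Compound 4 is therefore estimated at 0.1%, within -4% to 5%.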

Compound 4, a percentage reported as inhibition, at one concentration (the size of the read-out at that concentration, not a potency): 0.08%
Compound 4: the middle estimate sits 0 percentage points above what was measured, within the range that was stated.
By their numbers in this assay, from the lowest: compounds 2, 3, 4 and 1 (each within the scatter of the next).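

Within the core of compound 1, the change on the amine nitrogen from propyl to butyl gives in this assay a number 0 percentage points lower from compound 1 to compound 4 (within the scatter) and so stays inside the scatter. Among these compounds, this is the first read of methyl in place of hydrogen at this position, three bonds along the chain from an amine nitrogen, and the earlier step covered only cyclohexyl in place of sec-butyl on the other core. No measurement is at hand that bears on this result.

Still open, on these data alone, is whether a longer chain, or a carboxylic acid or an amine at the end of the chain, would move the number beyond the scatter.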